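A few compounds are considered here, and "the series" means these few. Any claim that something is new, unique, unknown or untested is made for them only; others in the source may bear on it.

Compound 1 `O=C(CCCCCCc1ccccc1)c1nc(C(F)(F)F)co1` and compound 2 `CC(=O)c1cnc(C(=O)CCCCCCc2ccccc2)o1` share a core built on a five-membered aromatic ring that carries a long ketone chain ending in a phenyl group. Both were tested in an assay on HEK-293T cells for inhibition of diacylglycerol lipase-alpha (Homo sapiens), read by colorimetric assay; on this read-out higher numbers stand for weaker inhibition and lower numbers for stronger inhibition. Compound 1 gives 214 nM. For compound 2 the result is a limit of the method, not a number: compound 2 gives > 10000 nM. Among the two values shown, compound 2 stands at the limit of > 10000 nM in this assay, at which 1 of the 2 values shown sits, so it is the one compound for which no exact figure exists, and its inhibition is weaker than that of compound 1.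

Compound 3 `Cc1ccc(-c2cnc(C(=O)CCCCCCc3ccccc3)o2)nc1` has not yet been measured. It differs from compound 2 in one place: 5-methylpyridin-2-yl in place of acetyl on an aromatic carbon.

Among the measured compounds shown here, no measured pair shows what this particular change does, so the expectation rests only on the two values above. In this assay compound 3 is expected to inhibit more strongly than compound 2, with an estimated step of an at least 5.0-fold lower number from compound 2 to compound 3 (0.69 log units; beyond the scatter), a step beyond the usual scatter. The estimate for compound 3 is 2000 nM, with a range from 300 nM to 10000 nM.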

Compound 3, half-maximal inhibitory concentration: > 10000 nM
Compound 3: only a limit was reported; the forecaster's own chance of this, stated with the estimate: 30%; middle value at least 5.0-fold (0.69 log units) away from the limit.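

In this assay compound 3 gives > 10000 nM, which is a limit of the method and not a number. Among the compounds shown here, compound 2 also ends at a limit, so no step between compound 2 and compound 3 can be read: the limit of > 10000 nM in this assay, at which 2 of the 3 values shown sit. The compounds shown leave open whether 5-methylpyridin-2-yl in place of acetyl changes inhibition at all.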